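The source may report more compounds than this note shows. Statements on the series, on what has been measured and on what is new or still open speak of the compounds shown alone.

Three compounds have been measured in a toxicity assay on HepG2 cells (Homo sapiens) for inhibition, read by CellTiter-Glo, with a stated time of 48 h; on this read-out lower numbers stand for stronger inhibition and higher numbers for weaker inhibition:

compound 1 `COc1ccc2nc(C)cc(OCC(=O)Nc3cc(C)cc(C)c3)c2c1`, 20000 nM
compound 2 `COc1ccc2c(OCC(=O)Nc3cc(C)cc(C)c3)cc(C)nc2c1`, 50100 nM
compound 3 `Cc1cc(C)cc(NC(=O)COc2cc(C)nc3ccc(F)cc23)c1`, 63100 nM

Compound 3 gives the highest of the three numbers in this assay. Its nearest neighbour is compound 2, which lies within the scatter of it, so the two cannot be ordered; compound 1 sits further off, and the step of a 3.2-fold higher number from compound 1 to compound 3 (0.50 log units; beyond the scatter) is beyond the scatter. Among the compounds with values here, that step is the only single change recorded here, and it lies at the same aromatic carbon that is altered next.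

Compound 4 `Cc1cc(C)cc(NC(=O)COc2cc(C)nc3ccc(C(F)(F)F)cc23)c1` differs from compound 3 by trifluoromethyl in place of fluoro on an aromatic carbon. Within the data shown here, no measured pair shows this exchange, so the step from compound 1 to compound 3 is the closest guide, and it concerns a different leaving group. Given that compound 3 already stands at 63100 nM, the change is expected to move the number little, with a 1.1-fold higher number from compound 3 to compound 4 (0.05 log units; within the scatter) anticipated to stay within the scatter. Compound 4 is therefore estimated at 70000 nM in this assay, within a range from 30000 nM to 160000 nM.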

Compound 4, half-maximal inhibitory concentration: > 100000 nM
Compound 4: no number, only a limit; the forecaster's own chance of this, stated with the estimate: 25%; middle value at least 1.4-fold (0.15 log units) away from the limit.
By their numbers in this assay, from the lowest: compound 1; then compounds 2 and 3 (each within the scatter of the next). At a limit, above all of these: compound 4.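

Compound 4 is read only as a limit of the assay in this assay, not as a number: the limit of > 100000 nM in this assay, at which 1 of the 4 values shown sits. The step is an at least 1.5-fold higher number from compound 3 to compound 4 (0.19 log units; that floor lies within the scatter), so this limit does not separate trifluoromethyl from fluoro at this aromatic carbon. Against methoxy the picture is firmer: the step is an at least 5.0-fold higher number from compound 1 to compound 4 (0.69 log units; beyond the scatter), which joins a 3.2-fold higher number from compound 1 to compound 3 (0.50 log units; beyond the scatter) in showing that both replacements of methoxy at this position give a higher number beyond the scatter.

Going by these compounds, the true size of the number for compound 4 stays unknown, and so does whether the trifluoromethyl exchange would have the same outcome on the core of compound 2. The compounds shown also leave open how an amine, a nitrile or a carboxylic acid on this aromatic carbon would read.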